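Dichlorophenyl Variation of a Chalcone Dithiocarbamate in ECa-109 Cells

The source may report more compounds than this note shows. Statements on the series, on what has been measured and on what is new or still open speak of the compounds shown alone.

Measured so far:
compound 1 `CN1CCN(C(=S)SCCCOc2ccc(C(=O)/C=C/c3ccc(Cl)cc3)cc2)CC1`: 34200 nM
compound 2 `O=C(/C=C/c1cccs1)c1ccc(OCCSC(=S)N2CCCC2)cc1`: 18300 nM

Of the compounds shown here, two have been measured in a functional assay on ECa-109 cells for inhibition, with ECa-109 cell line (Homo sapiens) as the target, read by MTT assay, with a stated time of 72 h; on this read-out higher numbers stand for weaker inhibition and lower numbers for stronger inhibition. Compound 1 gives 34200 nM in this assay, and compound 2 gives 18300 nM. Of the two numbers, compound 1 holds the higher one, but the gap to compound 2 lies within the scatter of repeated measurements, so no order between them can be claimed.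

Compound 3 `CN1CCN(C(=S)SCCCOc2ccc(C(=O)/C=C/c3cc(Cl)cc(Cl)c3)cc2)CC1` has not yet been measured. It differs from compound 1 in one place: 3,5-dichlorophenyl in place of 4-chlorophenyl on a double-bonded chain carbon bound to a double-bonded chain carbon. Within the data shown here, no measured pair carries this change, so nothing measured shows its effect. The step of a 1.2-fold lower number from compound 1 to compound 3 (0.09 log units; within the scatter) is expected to be small, most likely within the scatter, with at most a slight lean toward a lower number. Compound 3 is therefore expected to give about 28000 nM in this assay, with a range from 10000 nM to 80000 nM.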

Compound 3, half-maximal inhibitory concentration: 12400 nM
For compound 3 the middle estimate is 2.3-fold (0.35 log units) above the measured one, within the range that was stated.
By their numbers in this assay, from the lowest: compounds 3, 2 and 1 (each within the scatter of the next, the first and the last beyond it).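

In this assay, among these compounds, the step of a 2.8-fold lower number from compound 1 to compound 3 (0.44 log units; beyond the scatter) gives the first comparison of compounds that differ in one place. It shows that the group on this double-bonded chain carbon affects the read-out, as 3,5-dichlorophenyl in place of 4-chlorophenyl gives modestly stronger inhibition with the rest of the structure unchanged. No measurement at hand offers an explanation for this step.

The compounds shown do not separate the effect of adding a second chlorine from the effect of moving chlorine away from the position it holds in 4-chlorophenyl, which a 3-chlorophenyl group at the same place could address. They also leave open whether the trend extends to other substituents, such as those of a 3,5-dimethoxyphenyl or 3,5-dibromophenyl group.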